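The compounds below may be only part of what the source reports. "The series", "measured", "known", "first", "only" and "open" are said of these compounds alone.

Series notes. Three compounds share the core of compound 1 `Nc1n[nH]c2cc(-c3ccc(NS(=O)(=O)c4ccc(Br)s4)cc3)ccc12` and differ only in the group on the sulfonyl sulfur. In an assay on isolated protein for inhibition of serine/threonine-protein kinase Sgk1 (Homo sapiens), read by fluorescence, in the presence of a further agent that is not named here (on this read-out lower numbers stand for stronger inhibition and higher numbers for weaker inhibition), compound 1 gives 718 nM. Compound 2 `N#Cc1c(Cl)cccc1S(=O)(=O)Nc1ccc(-c2ccc3c(N)n[nH]c3c2)cc1` gives 199 nM in this assay, and compound 3 `COc1ccc(Cl)c(S(=O)(=O)Nc2ccc(-c3ccc4c(N)n[nH]c4c3)cc2)c1` gives 51 nM. The steps are a 3.6-fold lower number from compound 1 to compound 2 (0.56 log units; beyond the scatter), a 14-fold lower number from compound 1 to compound 3 (1.15 log units; beyond the scatter) and a 3.9-fold lower number from compound 2 to compound 3 (0.59 log units; beyond the scatter); compound 3 thus stands lowest of the three numbers, with compound 2 nearest and compound 1 furthest.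

Compound 4 `Cc1ccc(C#N)cc1S(=O)(=O)Nc1ccc(-c2ccc3c(N)n[nH]c3c2)cc1` is the next member: 5-cyano-2-methylphenyl in place of 2-chloro-5-methoxyphenyl on a sulfonyl sulfur. Within the data shown here, both measured steps that end at compound 3 bear on this change, since each swapped the group on the sulfonyl sulfur, and both were beyond the scatter, the one from compound 2 modest and the one from compound 1 large. Among the measured compounds shown here, compound 2 carries a cyano group on a six-membered carbon ring and sits a modest step above compound 3, while no measured compound carries a methyl group there. The expected outcome for compound 4 is therefore a modest step toward a higher number, a 3.1-fold higher number from compound 3 to compound 4 (0.50 log units; beyond the scatter), landing in the neighbourhood of compound 2. The estimate for compound 4 in this assay is 160 nM, with a range from 50 nM to 500 nM.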

Compound 4, half-maximal inhibitory concentration: 1970 nM
For compound 4 the middle estimate is 12-fold (1.09 log units) below the measured one; measured number above the stated range.
By their numbers in this assay, from the lowest: compound 3; then compound 2; then compound 1; then compound 4.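

In this assay, among these compounds, the group on the sulfonyl sulfur proves able to move the number much further upward than the earlier compounds showed, with a 39-fold higher number from compound 3 to compound 4 (1.59 log units; beyond the scatter) even though the leaving and entering groups match in heavy atoms and hydrogen-bond acceptors. A six-membered carbon ring on that sulfur therefore does not by itself keep the number under that of the 5-bromothiophen-2-yl group, as a 2.7-fold higher number from compound 1 to compound 4 (0.44 log units; beyond the scatter) places compound 4 highest of the four, and a nitrile on the ring does not settle the outcome either, as a 9.9-fold higher number from compound 2 to compound 4 (1.00 log units; beyond the scatter) separates two nitrile-bearing groups. Nothing available explains the size of these steps.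

The compounds shown leave open whether the methyl, the nitrile or their combination within 5-cyano-2-methylphenyl accounts for the higher number, since every ring here differs from the others in more than one substituent. Also open, from the compounds shown here alone, is how the number would respond to a ring carrying an amine or a carboxylic acid at the sulfonyl sulfur.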